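The compounds below may be only part of what the source reports. "The series", "measured", "known", "first", "only" and "open" are said of these compounds alone.

Compound 1 `CC(C)=CCC1Cc2c(OCCCNC(=O)c3ccco3)cc(=O)n(CCCO)c2CC1(C)C`: 4.3%
Compound 2 `CC(C)=CCC1Cc2c(OC(=O)Nc3ccc(F)cc3)cc(=O)n(CCCO)c2CC1(C)C`: 0%

Going by the values given here, in a functional assay on PANC-1 cells (Homo sapiens) for inhibition, read by MTT assay, with a stated time of 24 h, tested at 10 uM (a higher number here means more inhibition at the concentration tested (going by the name of the read-out), a lower number less inhibition), compound 2 gives 0%; compound 1 gives 4.3%, and the one step measured, a number 4.3 percentage points lower from compound 1 to compound 2 (within the scatter), lies within the scatter, so the two numbers cannot be told apart. Compound 3 `CC(C)=CCC1Cc2c(OC(=O)Nc3ccc(F)cc3F)cc(=O)n(CCCO)c2CC1(C)C` differs from compound 2 by fluoro in place of hydrogen on an aromatic carbon, so that the 4-fluorophenyl group becomes a 2,4-difluorophenyl group. Among the compounds with values here, no measured step covers an added fluoro, and the single step available shows only flat numbers near zero. A further step a number 3 percentage points higher from compound 2 to compound 3 (within the scatter) is expected to stay within the scatter. Compound 3 is therefore estimated at 3%, between 0% and 15%.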

Compound 3, a percentage reported as inhibition, at one concentration (the size of the read-out at that concentration, not a potency): 0%
Compound 3: the middle estimate sits 3 percentage points above what was measured; the range from low to high includes it.
By their numbers in this assay, from the lowest: compounds 2, 3 and 1 (each within the scatter of the next).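

In this assay, a second fluoro on the aromatic carbon ortho to a large group turns 4-fluorophenyl into 2,4-difluorophenyl and gives a flat result (no change at the digits printed from compound 2 to compound 3 (within the scatter)), so this position accepts the fluoro with no readable effect on a number already at the bottom of the range. Replacing the 3-(((furan-2-yl)carbonyl)amino)propyl group with (2,4-difluorophenyl)carbamoyl also cannot be read as a real difference (a number 4.3 percentage points lower from compound 1 to compound 3 (within the scatter)). No supporting measurement bears on these results.

Still open, from the compounds shown here alone, is whether an amine or a carboxylic acid on this aromatic ring would give a number clearly beyond the scatter.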